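Methoxyphenyl isomers on a bis(trifluoromethyl)benzenesulfonamide chain

The source may hold more compounds than are shown below. What is called first, only, known or untested is meant among the compounds shown, and "the series" means these compounds.

Compound 1 `O=S(=O)(NCCCNCc1cccc2ccccc12)c1cc(C(F)(F)F)cc(C(F)(F)F)c1`: 2700 nM
Compound 2 `COc1ccc(CNCCCNS(=O)(=O)c2cc(C(F)(F)F)cc(C(F)(F)F)c2)cc1`: 11000 nM

In a functional assay on PANC-1 cells (Homo sapiens) for inhibition, read by MTT assay, with a stated time of 72 h (on this read-out lower numbers stand for stronger inhibition of growth and higher numbers for weaker inhibition of growth), compound 2 gives 11000 nM, the highest of the two numbers; its nearest neighbour, compound 1, gives 2700 nM. For the measured compounds named here, the one measured step, a 4.1-fold higher number from compound 1 to compound 2 (0.61 log units; beyond the scatter), was modest. Compound 3 `COc1cccc(CNCCCNS(=O)(=O)c2cc(C(F)(F)F)cc(C(F)(F)F)c2)c1` differs from compound 2 by 3-methoxyphenyl in place of 4-methoxyphenyl on a saturated chain carbon bound to an amine nitrogen. Going by the values given here, no measured step bears on this change, so compound 3 is expected to give a number close to compound 2, with no step beyond the scatter. Compound 3 is estimated at 9000 nM, between 3000 nM and 30000 nM, meaning an expected 1.2-fold lower number from compound 2 to compound 3 (0.09 log units; within the scatter).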

Compound 3, concentration for 50% growth inhibition: 10000 nM
Estimate against measurement, compound 3: 1.1-fold (0.05 log units) below, within the range that was stated.
By their numbers in this assay, from the lowest: compound 1; then compounds 3 and 2 (each within the scatter of the next).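

In this assay, 3-methoxyphenyl in place of 4-methoxyphenyl gave a 1.1-fold lower number from compound 2 to compound 3 (0.04 log units; within the scatter) and so left the number unchanged within the scatter: on this saturated chain carbon, these two methoxyphenyl isomers cannot be told apart. The gap to naphthalen-1-yl held for the second isomer too, with a 3.7-fold higher number from compound 1 to compound 3 (0.57 log units; beyond the scatter) as its size. No evidence here accounts for either step. The compounds shown leave open how 2-methoxyphenyl or naphthalen-2-yl would read at this position, and whether a longer chain would change the number.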